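Carboxy in Place of Tetrazole: Expected Cost in Dose

The compounds below may be only part of what the source reports. "The series", "measured", "known", "first", "only" and "open" are said of these compounds alone.

Compound 1 `O=C(O)c1ccc(NC(=O)c2ccc(C(=O)O)cc2)cc1`: 54.3 mg/kg in a functional assay on the whole organism (stomach) with Rattus norvegicus as the target; a higher number here means that more compound is needed for the effect, a lower number that less compound is needed
Compound 2 `O=C(O)c1ccc(NC(=O)c2ccc(-c3nn[nH]n3)cc2)cc1`: 3.5 mg/kg in this assay
Compound 3 `O=C(O)c1cc(NC(=O)c2ccc(-c3nn[nH]n3)cc2)cc(C(=O)O)c1`: 8.2 mg/kg in this assay

Compound 4 `O=C(O)c1ccc(C(=O)Nc2cc(C(=O)O)cc(C(=O)O)c2)cc1` is not yet measured. It arises from compound 3 by a single change, (carboxy in place of 2H-tetrazol-5-yl on an aromatic carbon). The same change, (carboxy in place of 2H-tetrazol-5-yl on an aromatic carbon), turns compound 2 into compound 1, and there it made a 16-fold higher number from compound 2 to compound 1 (1.19 log units; beyond the scatter). Within the data shown here, how the core of compound 3 differs from that of compound 2 is not broken down here; the values show only that compound 3 needs a higher dose than compound 2 in this assay. Since the change and its place are the same as in the measured pair, a step of similar size is expected, resting on compound 1 with a 16-fold higher number from compound 2 to compound 1 (1.19 log units; beyond the scatter). The expected step is a 15-fold higher number from compound 3 to compound 4 (1.17 log units; beyond the scatter). For compound 4 the estimate in this assay is 120 mg/kg, likely between 45 mg/kg and 320 mg/kg.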

Compound 4, dose for 50% inhibition: 32.2 mg/kg
The estimate for compound 4 lay 3.7-fold (0.57 log units) above the measured number, and the stated range ends above it.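

In this assay the swap of 2H-tetrazol-5-yl for carboxy gives a 3.9-fold higher number from compound 3 to compound 4 (0.59 log units; beyond the scatter) and so again raises the dose needed, which means the direction of the change carries over to the second core. The size of the step does not carry over, and the gap is larger than repeated measurements would explain: the same change on two cores in this assay, a 16-fold higher number (1.19 log units; beyond the scatter) from compound 2 to compound 1 and a 3.9-fold higher number (0.59 log units; beyond the scatter) from compound 3 to compound 4, 4.0-fold (0.60 log units) apart, beyond the scatter of two such steps. Two pairs show that the core can alter the size of the step, but they do not show which part of the core matters or how large the step would be on a third core.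

The compounds shown leave open how an amine or a methyl ester on that aromatic carbon would compare with carboxy and 2H-tetrazol-5-yl. They also leave open whether other changes depend on the core in the same way.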